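This account rests on a few compounds, and the source may have more. Where it says the series, first, only, none or still open, it means among the compounds named here.

Measured so far:
compound 1 `COc1ccc2c(=O)c(/C=C/C(=O)Nc3ccc(C)cc3)coc2c1` gives 39300 nM
compound 2 `COc1ccc2c(=O)c(/C=C/C(=O)Nc3ccccc3)coc2c1` gives 14000 nM
compound 3 `COc1ccc2c(=O)c(/C=C/C(=O)NCc3ccc(F)cc3)coc2c1` gives 7960 nM

All three were run in a functional assay (QGY7701 cells, Homo sapiens) for inhibition, read by MTT assay, with a stated time of 48 h; a higher number here means a weaker inhibitor, a lower number a stronger inhibitor. Compound 1 stands at the highest of the three numbers; the nearest is compound 2, with a 2.8-fold lower number from compound 1 to compound 2 (0.45 log units; beyond the scatter), and the furthest is compound 3, with a 4.9-fold lower number from compound 1 to compound 3 (0.69 log units; beyond the scatter). Between the other two, a 1.8-fold lower number from compound 2 to compound 3 (0.25 log units; within the scatter).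

Compound 4 `COc1ccc(NC(=O)/C=C/c2coc3cc(OC)ccc3c2=O)cc1` is not yet measured. It differs from compound 1 in one place: methoxy in place of methyl on an aromatic carbon. Among the compounds with values here, no measured step swaps one substituent for another on this aromatic ring; the only step touching this ring is the one from compound 1 to compound 2, which removed the methyl and gave a modest fall. That step bears only loosely on a methoxy entering in its place, and nothing measured addresses the methoxy itself. The expectation for compound 4 is therefore a small step, most likely toward a somewhat lower number but possibly none beyond the scatter: a 1.6-fold lower number from compound 1 to compound 4 (0.20 log units; within the scatter) is estimated. Compound 4 is expected to give about 25000 nM, within 8000 nM to 80000 nM.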

Compound 4, half-maximal inhibitory concentration: > 100000 nM
Compound 4: only a limit was reported; the forecaster's own chance of this, stated with the estimate: 10%; middle value at least 4.0-fold (0.60 log units) away from the limit.
By their numbers in this assay, from the lowest: compounds 3 and 2 (each within the scatter of the next); then compound 1. At a limit, above all of these: compound 4.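

In this assay compound 4 carries a limit and not a number: the limit of > 100000 nM in this assay, at which 1 of the 4 values shown sits.

Within the data shown here, this aromatic carbon, para to a large group, responds far more to the incoming methoxy than the earlier compounds suggested: methoxy in place of methyl gives an at least 2.5-fold higher number from compound 1 to compound 4 (0.40 log units; beyond the scatter), and methoxy in place of hydrogen gives an at least 7.1-fold higher number from compound 2 to compound 4 (0.85 log units; beyond the scatter). The steps go in opposite directions on the same carbon, since removing the methyl lowered the number while adding the methoxy raises it, and 4-methoxyphenyl in place of 4-fluorobenzyl gives an at least 12-fold higher number from compound 3 to compound 4 (1.09 log units; beyond the scatter).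

Whether the rise follows the oxygen of the methoxy or the larger group as a whole stays open, as no hydroxyl, amine or ethoxy on this carbon stands among the compounds shown. As far as these compounds go, the true value of compound 4 also remains unknown, so the full size of these steps cannot be given.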